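The source may report more compounds than this note shows. Statements on the series, on what has been measured and on what is new or still open speak of the compounds shown alone.

Compound 1 `O=c1cc(-n2cc(COc3ccccc3)nn2)c2cc(Br)ccc2o1`, compound 2 `O=c1cc(-n2cc(COc3ccc(Br)cc3)nn2)c2cc(Br)ccc2o1` and compound 3 `O=c1cc(-n2cc(COc3ccc(F)cc3)nn2)c2cc(Br)ccc2o1` share one core and differ only in the group on the phenoxy ring. In a functional assay on SW480 cells (Homo sapiens) for antiproliferative activity, read by MTT assay, with a stated time of 48 h (a higher number here means a weaker inhibitor, a lower number a stronger inhibitor), compound 2 gives 1310 nM, compound 3 gives 1770 nM, and compound 1 gives 4990 nM. The difference between compound 2 and compound 3 is fluoro in place of bromo on an aromatic carbon, a step of a 1.4-fold higher number from compound 2 to compound 3 (0.13 log units; within the scatter). The change hydrogen in place of bromo on an aromatic carbon gave a 3.8-fold higher number from compound 2 to compound 1 (0.58 log units; beyond the scatter). Compound 4 `O=c1cc(-n2cc(COc3ccc(F)cc3)nn2)c2ccccc2o1` arises from compound 3 by hydrogen in place of bromo on an aromatic carbon; this is the same kind of change as from compound 2 to compound 1, yet the place differs, being part of a fused or bridged system of two rings, meta and para to a fused ring, rather than para to a large group. Resting on compound 2 with a 3.8-fold higher number from compound 2 to compound 1 (0.58 log units; beyond the scatter), the expected step is a 2.5-fold higher number from compound 3 to compound 4 (0.41 log units; beyond the scatter), so compound 4 is estimated at 4500 nM, between 1500 nM and 14000 nM.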

Compound 4, half-maximal inhibitory concentration: 3820 nM
Estimate against measurement, compound 4: 1.2-fold (0.07 log units) above; the measured number falls inside the stated range.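

In this assay, hydrogen in place of bromo on the two-ring system of the core gave a 2.2-fold higher number from compound 3 to compound 4 (0.33 log units; beyond the scatter). Set beside the same swap on the phenoxy ring, the step points the same way and its size cannot be told apart from the earlier one: the same change on two cores in this assay, a 3.8-fold higher number (0.58 log units; beyond the scatter) from compound 2 to compound 1 and a 2.2-fold higher number (0.33 log units; beyond the scatter) from compound 3 to compound 4, 1.8-fold (0.25 log units) apart, within the scatter of two such steps

This shows that losing a bromo weakened the compound in both pairs, so the change carried over here. Going by these compounds alone, it does not show that it would carry to other cores, since only two pairs stand here, or why either step occurs.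

The compounds shown leave open whether an amine or a carboxylic acid in place of that bromo would follow the same direction. On these data alone, whether other cell lines would respond alike also stays open.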